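Phenoxy for methoxy on the amide aryl ring

The source may hold more compounds than are shown below. What is called first, only, known or untested is meant among the compounds shown, and "the series" means these compounds.

Compound 1 `COc1ccc(C(=O)NC(CCN(C)C)c2ccc(Cl)cc2)cc1` is one of two compounds with a number in an assay on NIH3T3 cells with Urotensin-2 receptor (Homo sapiens) as the target; on this read-out higher numbers stand for an effect only at larger amounts of compound and lower numbers for an effect already at smaller amounts; compound 1 gives 1350 nM, the lowest of the two. Compound 2 `Cc1cccc(C(=O)NC(CCN(C)C)c2ccc(Cl)cc2)c1C` gives 3630 nM, and the change a 2.7-fold higher number from compound 1 to compound 2 (0.43 log units; beyond the scatter) shows a modest shift. Compound 3 `CN(C)CCC(NC(=O)c1ccc(Oc2ccccc2)cc1)c1ccc(Cl)cc1` has not yet been measured in this assay. It differs from compound 1 in one place: phenyl in place of methyl on an oxygen on an aromatic ring. Going by the values given here, the one measured step concerns a different change on the same carbonyl-attached ring, where two methyl groups took the place of the methoxy group and moved the number up modestly. Among the compounds with values here, no measured step enlarges the methoxy group itself, so the data give no direct guide to what a phenoxy group does here, and a small shift in either direction is as plausible as none. Compound 3 is therefore expected to give roughly 1500 nM, with a range from 400 nM to 5500 nM. The corresponding step of a 1.1-fold higher number from compound 1 to compound 3 (0.05 log units; within the scatter) is expected to stay within the usual scatter.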

Compound 3, half-maximal effective concentration: 66.1 nM
Estimate against measurement, compound 3: 23-fold (1.36 log units) above; measured number outside the range, below it.
By their numbers in this assay, from the lowest: compound 3; then compound 1; then compound 2.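

The group on the oxygen on the aromatic ring turns out to be a highly sensitive place in this assay: replacing methyl with phenyl gives a 20-fold lower number from compound 1 to compound 3 (1.31 log units; beyond the scatter), a large change from a single swap that adds one six-membered aromatic ring of carbon only. The earlier step, a 2.7-fold higher number from compound 1 to compound 2 (0.43 log units; beyond the scatter), showed only a modest change on the same carbonyl-attached ring and gave no sign that a change at this oxygen could lower the number so sharply, so compound 3 now has the lowest number of the three compounds. No measured evidence shown here accounts for the size of this drop.

Going by these compounds alone, with only this one phenoxy example, it remains open whether the number depends on an aromatic ring at this place, which a comparison with a cyclohexyloxy group could test, or on the ring being joined directly to the oxygen, which a benzyloxy group could test. As far as these compounds go, it is also open how the number would respond to a fluorine, a chlorine or a methoxy group on the added phenyl ring.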